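Swapping a thiazolyl arm for a pyridinyl arm

The compounds below may be only part of what the source reports. "The series", "measured", "known", "first", "only" and "open" are said of these compounds alone.

Three compounds have been measured in a functional assay on U-87MG ATCC cells for antiproliferative activity against U-87 MG (Homo sapiens), read by MTT assay, with a stated time of 48 h; on this read-out lower numbers stand for stronger inhibition and higher numbers for weaker inhibition:
compound 1 `O=C(/C=C/c1ccc(Oc2cc(=O)oc3ccccc23)cc1)/C=C/c1ccccn1` gives 50800 nM
compound 2 `COc1cc(OC)c2c(=O)c(OCCCOc3ccc(/C=C/C(=O)/C=C/c4scnc4C)cc3)c(-c3cc(OC)c(OC)c(OC)c3)oc2c1` gives 40400 nM
compound 3 `COc1cc(OC)c2c(=O)c(OCCCCOc3ccc(/C=C/C(=O)/C=C/c4scnc4C)cc3)c(-c3cc(OC)c(OC)c(OC)c3)oc2c1` gives 58700 nM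

Compound 3 holds the highest number of the three, yet its gap to compound 1 and its gap to compound 2 both lie within the usual scatter of repeated measurements, so the three values cannot be told apart. Compound 4 `COc1cc(OC)c2c(=O)c(OCCCCOc3ccc(/C=C/C(=O)/C=C/c4ccccn4)cc3)c(-c3cc(OC)c(OC)c(OC)c3)oc2c1` keeps the whole of compound 3 except at one place: pyridin-2-yl in place of 4-methyl-1,3-thiazol-5-yl on a double-bonded chain carbon bound to a double-bonded chain carbon. Among the compounds with values here, no step between two measured compounds with this same change is available, so nothing shows directly how the swap reads on this scale. Compound 1 carries a pyridin-2-yl at the corresponding place on a different core and gives 50800 nM, a number that sits within the scatter of the value of compound 3, which offers no hint of a shift in either direction. On this basis the step is expected to stay inside the scatter, with no direction favoured, and the estimated step is a 1.2-fold lower number from compound 3 to compound 4 (0.07 log units; within the scatter). Compound 4 is therefore expected to give 50000 nM in this assay, within a range from 20000 nM to 150000 nM.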

Compound 4, half-maximal inhibitory concentration: 4690 nM
For compound 4 the middle estimate is 11-fold (1.03 log units) above the measured one; the whole stated range lies above it.
By their numbers in this assay, from the lowest: compound 4; then compounds 2, 1 and 3 (each within the scatter of the next).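

In this assay, within the data shown here, the arm on a double-bonded chain carbon bound to a double-bonded chain carbon proves to be a place where the number can move: pyridin-2-yl in place of 4-methyl-1,3-thiazol-5-yl gives a 13-fold lower number from compound 3 to compound 4 (1.10 log units; beyond the scatter) and is the first step in this set to pass beyond the scatter. The earlier compounds shown here could not show this, since their values could not be told apart and no two of them differed at this place alone. The size of the step also comes without any change in the heavy-atom count of the arm, as a five-membered aromatic ring with 2 hetero atoms leaves and a six-membered aromatic ring with 1 hetero atom enters, so the ring size, the sulfur and the methyl group all change together and cannot be separated here.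

As far as these compounds go, whether a phenyl or a pyridin-3-yl at this place would give a number like that of compound 4 stays open, as does whether the same swap reads alike on the chain of compound 2. Nothing measured here bears on the reason for this step.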